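Ring-moved methyl in a cytotoxicity series

The compounds below may be only part of what the source reports. "The series", "measured", "known", "first", "only" and "open" are said of these compounds alone.

Measured compounds:
compound 1 `O=C1NC2=C(C(=O)OC2)C(c2cccc(O)c2)N1` with > 10000 nM
compound 2 `CCC1=C(C(=O)CCC2CCCCC2)[C@H](c2ccc(O)c(Cl)c2)NC(=O)N1` with > 10000 nM

Of the compounds shown here, two have been tested in an ADME assay on cells (Homo sapiens) for cytotoxicity; on this read-out higher numbers stand for lower toxicity in this test and lower numbers for higher toxicity in this test. Compound 1 `O=C1NC2=C(C(=O)OC2)C(c2cccc(O)c2)N1` was measured only as a limit of the assay, > 10000 nM. Compound 2 `CCC1=C(C(=O)CCC2CCCCC2)[C@H](c2ccc(O)c(Cl)c2)NC(=O)N1` likewise reached only a limit, > 10000 nM. Both values thus sit at the limit of > 10000 nM in this assay, at which 2 of the 2 values shown sit, and no numbered difference between them can be read.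

Compound 3 `CCC1=C(C(=O)CC2CCC(C)CC2)[C@H](c2ccc(O)c(Cl)c2)NC(=O)N1` has not yet been measured in this assay. It differs from compound 2 by 4-methylcyclohexyl in place of cyclohexylmethyl on a saturated chain carbon bound to a carbonyl carbon: the same atoms are joined differently, so that 4-methylcyclohexyl stands in place of cyclohexylmethyl on the saturated chain carbon bound to the carbonyl carbon.

Among the measured compounds shown here, no step between measured compounds is available to guide the expectation. Since compound 2 gave only a limit, > 10000 nM, the step from compound 2 to compound 3 is expected to be a number no higher from compound 2 to compound 3 (the limit leaves the size open), that is, none beyond the scatter. Compound 3 is therefore estimated at 10000 nM, within a range from 4000 nM to 30000 nM, most likely again reported as a limit.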

Compound 3, half-maximal cytotoxic concentration: > 10000 nM
Compound 3 ended at the assay's limit; the forecaster's own chance of this, stated with the estimate: 80%; the middle value sits exactly at the limit.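

In this assay, compound 2 and compound 3 both reached only a limit, so no step between them can be read: the limit of > 10000 nM in this assay, at which 3 of the 3 values shown sit.

The compounds shown leave open whether 4-methylcyclohexyl in place of cyclohexylmethyl changes this read-out at all, and where any of the three compounds would give an actual number.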